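A few compounds are considered here, and "the series" means these few. Any claim that something is new, unique, unknown or untested is made for them only; others in the source may bear on it.

Compound 1 `Cn1ncc2c(=O)n(-c3ccccc3)c(COc3cccc(F)c3)nc21` gives 780 nM in an assay on isolated protein for inhibition of Retinaldehyde dehydrogenase 3 (Homo sapiens); a lower number here means a stronger inhibitor, a higher number a weaker inhibitor.
Compound 2 `CC(Sc1nc2c(cnn2C)c(=O)n1-c1ccc(CCO)cc1)c1ccccc1` gives 3000 nM in this assay.
Compound 3 `CC(Sc1nc2c(cnn2C)c(=O)n1-c1ccc(CO)cc1)c1ccccc1` gives 1000 nM in this assay.

Among these three numbers compound 3 holds the second highest. Its nearest neighbour is compound 1, whose value sits within the scatter of that of compound 3, so no order between the two can be claimed. Among the compounds with values here, compound 2 lies furthest away, and the one measured step, a 3.0-fold lower number from compound 2 to compound 3 (0.48 log units; beyond the scatter), shows that shortening the substituent on the phenyl ring of the shared core brought a modest gain.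

Compound 4 `CC(Sc1nc2c(cnn2C)c(=O)n1-c1ccc(C#N)cc1)c1ccccc1` carries a different substituent at that same place: cyano in place of hydroxymethyl on an aromatic carbon. The step from compound 2 to compound 3 is the only one that touches this position, and it swapped one hydroxyl-bearing group for another. Within the data shown here, no measured step shows what happens when the group loses its donor and takes on a triple bond, so the earlier step can only hint that this position tolerates small changes without large swings.

The expectation for compound 4 is therefore a value close to that of compound 3, with a 1.2-fold higher number from compound 3 to compound 4 (0.08 log units; within the scatter), and an estimate of 1200 nM with a range from 400 nM to 3600 nM.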

Compound 4, half-maximal inhibitory concentration: 200 nM
Compound 4: middle estimate off by 6.0-fold (0.78 log units), on the high side; measured number outside the range, below it.
By their numbers in this assay, from the lowest: compound 4; then compounds 1 and 3 (each within the scatter of the next); then compound 2.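

In this assay, the earlier step only compared two hydroxyl-bearing chains of different length, while the change from 4-(hydroxymethyl)phenyl to 4-cyanophenyl gives a clear gain (a 5.0-fold lower number from compound 3 to compound 4 (0.70 log units; beyond the scatter)), so this place also responds to the kind of group that sits there. Across the three compounds that differ only at this place, the full span is large (a 15-fold lower number from compound 2 to compound 4 (1.18 log units; beyond the scatter)), and the cyano group, with 0 hydrogen-bond donors, gives the lowest number of the three, though this single change cannot show which feature of the group matters. No independent measurement is available to explain why the number falls.

As far as these compounds go, it remains open whether the gain is particular to cyano or would also appear with an amine, a carboxylic acid, a fluorine atom or a methyl group on the same aromatic carbon. From the compounds shown here alone, it is also open whether the 4-cyanophenyl group would bring a similar gain on the core and side chain of compound 1, which differs from compound 4 in more than one place.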